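Shifting a fluorine on a shared core

The source may report more compounds than this note shows. Statements on the series, on what has been measured and on what is new or still open speak of the compounds shown alone.

Three compounds share one core and differ only in the aromatic group on it. Compound 1 `O=C1CSC(c2ccc(O)cc2)N1CCN1CCCCC1` gives 100% in an ADME assay on Vero cells (Chlorocebus sabaeus) for cytotoxicity, read by neutral red uptake, tested at 12.3 ug/mL; a lower number here means a stronger effect, a higher number a weaker effect of the compound at the concentration tested. Compound 2 `Cc1ccc(C2SCC(=O)N2CCN2CCCCC2)cc1` gives 100% in this assay, and compound 3 `O=C1CSC(c2ccc(F)cc2)N1CCN1CCCCC1` gives 100%. The steps of no change at the digits printed from compound 1 to compound 2 (within the scatter), no change at the digits printed from compound 1 to compound 3 (within the scatter) and no change at the digits printed from compound 2 to compound 3 (within the scatter) all stay within the scatter, so compound 3 sits level with compounds 1 and 2. Compound 4 `O=C1CSC(c2cccc(F)c2)N1CCN1CCCCC1` differs from compound 3 by 3-fluorophenyl in place of 4-fluorophenyl on a saturated ring carbon. Among the compounds with values here, none of the measured steps trades a 4-fluorophenyl for a 3-fluorophenyl, but every change to the aromatic group seen so far left the read-out unchanged, so no step beyond the scatter is expected here either. Compound 4 is therefore estimated to give 100%, between 90% and 100%, an expected step of no change at the digits printed from compound 3 to compound 4 (within the scatter).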

Compound 4, a percentage reported as activity, at one concentration (the size of the read-out at that concentration, not a potency): 100%
Beside the measured number, compound 4's estimate shows no gap at the digits printed; low and high end bracket the measured number.
By their numbers in this assay, from the lowest: compounds 1, 2, 3 and 4 (each within the scatter of the next).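

Until now only the group on the phenyl ring had changed. With 3-fluorophenyl in place of 4-fluorophenyl on a saturated ring carbon, this assay shows that moving the fluorine also leaves the read-out level (no change at the digits printed from compound 3 to compound 4 (within the scatter)), and the new compound stays level with the other two as well (no change at the digits printed from compound 2 to compound 4 (within the scatter); no change at the digits printed from compound 1 to compound 4 (within the scatter)). Nothing available explains this. Going by these compounds, it remains open whether an amine or a carboxylic acid on the phenyl ring, or a longer chain in place of the fluorine, would move this read-out.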